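Working notes: the amide nitrogen group in compound 3

The source may report more compounds than this note shows. Statements on the series, on what has been measured and on what is new or still open speak of the compounds shown alone.

Measured in a functional assay on LoVo cells (Homo sapiens) for antiproliferative activity, read by MTT assay, with a stated time of 72 h; on this read-out lower numbers stand for stronger inhibition and higher numbers for weaker inhibition:
- compound 1 `Cc1noc(C)c1-c1nn(Cc2ccc(C(=O)NC3CC(C)(C)N([O])C(C)(C)C3)cc2)c(=O)c2ccccc12`: 41200 nM
- compound 2 `Cn1cc(-c2nn(Cc3ccc(C(=O)NC4CC(C)(C)N([O])C(C)(C)C4)cc3)c(=O)c3ccccc23)cn1`: 50100 nM

Only these two compounds have been measured so far, and they cannot be separated: a 1.2-fold higher number from compound 1 to compound 2 (0.08 log units; within the scatter) lies within the scatter. Compound 1 therefore stands level with compound 2 on the numbers available.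

The next compound is compound 3 `Cc1noc(C)c1-c1nn(Cc2ccc(C(=O)NC3CCCCC3)cc2)c(=O)c2ccccc12`, which keeps the core of compound 1 and changes only the group on the amide-type nitrogen: a group of 6 heavy atoms (6 carbon; one six-membered non-aromatic ring of carbon only) in place of a group of 11 heavy atoms (9 carbon, 1 nitrogen, 1 oxygen; one six-membered non-aromatic ring with 1 hetero atom), on an amide-type nitrogen. Cyclohexyl enters, and the larger ring group leaves.

Within the data shown here, the one measured step, a 1.2-fold higher number from compound 1 to compound 2 (0.08 log units; within the scatter), replaces 3,5-dimethyl-1,2-oxazol-4-yl with 1-methyl-1H-pyrazol-4-yl on an aromatic carbon. It bears on this change only indirectly, since it is made at a different place. Among the measured compounds shown here, compounds 1 and 2 carry the same group on the amide-type nitrogen, so the data hold no measured step at that place.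

No step beyond the scatter is expected in this assay, and no direction can be assigned with confidence. The expected step is a 1.1-fold higher number from compound 1 to compound 3 (0.04 log units; within the scatter). For compound 3 the estimated value is 45000 nM, with an expected range of 15000 nM to 110000 nM.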

Compound 3, half-maximal inhibitory concentration: 82200 nM
For compound 3 the middle estimate is 1.8-fold (0.26 log units) below the measured one; the range from low to high includes it.
By their numbers in this assay, from the lowest: compounds 1, 2 and 3 (each within the scatter of the next).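

Among these compounds, the amide-type nitrogen now has its first measured step: in this assay, cyclohexyl in place of the larger ring group gives a 2.0-fold higher number from compound 1 to compound 3 (0.30 log units; within the scatter), whereas the earlier compounds differed only at the aromatic carbon. This read-out therefore does not separate the two groups at this place, so the larger group, with its ring nitrogen and its oxygen, is not shown to matter here, and a group of carbon only serves as a comparison for it. No measurement at hand bears on the reason for this result.

Still open, going by these compounds, is whether a group of another kind on the amide-type nitrogen, such as a chain ending in a primary amine or a carboxylic acid, or a short open chain such as n-butyl, would give a step beyond the scatter in this assay. Also open, on these data alone, is whether cyclohexyl on that nitrogen would give the same picture with 1-methyl-1H-pyrazol-4-yl in place of 3,5-dimethyl-1,2-oxazol-4-yl on the aromatic carbon.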